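From 4-(tert-butyl)phenyl to 3-(trifluoromethyl)phenyl: compound 3 ahead

The source may report more compounds than this note shows. Statements on the series, on what has been measured and on what is new or still open speak of the compounds shown alone.

In a functional assay on DU-145 cells (Homo sapiens) for antiproliferative activity, read by MTT assay, with a stated time of 48 h (a lower number here means a stronger inhibitor, a higher number a weaker inhibitor), compound 1 `C/C(=C\CC/C(C)=C/CC[C@@H]1[C@@]2(C)CCC(=O)C(C)(C)[C@H]2CC[C@@]1(C)O)CC/C=C(\C)C(=O)OCc1cn(-c2ccccc2)nn1` gives 95500 nM as its reading. Compound 2 `C/C(=C\CC/C(C)=C/CC[C@@H]1[C@@]2(C)CCC(=O)C(C)(C)[C@H]2CC[C@@]1(C)O)CC/C=C(\C)C(=O)OCc1cn(-c2ccc(C(C)(C)C)cc2)nn1` reads > 150000 nM which is a limit of the assay and not a number. Among the measured compounds shown here, this is the limit of > 150000 nM in this assay, at which 1 of the 2 values shown sits, so far, and compound 2 has no exact position.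

For the measured compounds named here, the only measured step is an at least 1.5-fold higher number from compound 1 to compound 2 (0.19 log units; that floor lies within the scatter) and it comes from tert-butyl in place of hydrogen on an aromatic carbon. Its size is a floor and not a measured gap.

Compound 3 `C/C(=C\CC/C(C)=C/CC[C@@H]1[C@@]2(C)CCC(=O)C(C)(C)[C@H]2CC[C@@]1(C)O)CC/C=C(\C)C(=O)OCc1cn(-c2cccc(C(F)(F)F)c2)nn1` brings the change 3-(trifluoromethyl)phenyl in place of 4-(tert-butyl)phenyl on an aromatic nitrogen with 3-(trifluoromethyl)phenyl in place of 4-(tert-butyl)phenyl on an aromatic nitrogen of a five-membered aromatic ring with 3 nitrogen. Going by the values given here, no measured step covers this swap directly. The closest reference lacking the tert-butyl is compound 1 at 95500 nM so a reading in that region is expected. The expected step is an at least 1.6-fold lower number from compound 2 to compound 3 (0.22 log units; that floor lies within the scatter) in this assay toward a lower number, modest in size and poorly bounded. A further limit reading remains possible. For compound 3 the estimated value is 90000 nM with an expected range from 40000 nM to 150000 nM at this stage.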

Compound 3, half-maximal inhibitory concentration: > 150000 nM
Compound 3 ended at the assay's limit; the forecaster's own chance of this, stated with the estimate: 30%; middle value at least 1.6-fold (0.22 log units) away from the limit.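

With 3-(trifluoromethyl)phenyl on the aromatic nitrogen, the series gives a second substituted aryl group that yields no exact reading in this assay: compound 3 gives > 150000 nM, which is a limit of the assay and not a number. Trifluoromethyl in place of hydrogen on the phenyl ring gives an at least 1.5-fold higher number from compound 1 to compound 3 (0.19 log units; that floor lies within the scatter), so neither substituted aryl group shown offers a measured gain over the plain phenyl of compound 1, although this floor does not establish a real loss. The step between compound 2 and compound 3 cannot be read, as both readings are limits, and the series now stands as follows: the limit of > 150000 nM in this assay, at which 2 of the 3 values shown sit.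

Among the compounds shown here, compound 1 remains the only exact reading, so the true gaps among the three aryl groups stay open, as does any separate contribution from the group's identity or its placement on the ring. Also open, going by these compounds, is how this assay would respond to an amine or a carboxylic acid on the phenyl ring, or to a longer chain in place of the phenyl on the aromatic nitrogen.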